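This account rests on a few compounds, and the source may have more. Where it says the series, first, only, none or still open, it means among the compounds named here.

Measured compounds:

Compound 1, `Cc1ccc2[nH]c(=O)c(/C=N/Nc3ccc([N+](=O)[O-])cc3)cc2c1`: 109000 nM
Compound 2, `NS(=O)(=O)CC(=O)N/N=C/c1cc2ccccc2[nH]c1=O`: 1290000 nM

Both compounds were tested in a functional assay, read by spectrophotometry, with a stated time of 30 min; on this read-out higher numbers stand for weaker inhibition and lower numbers for stronger inhibition. Of the two numbers, compound 1 holds the lower one, and the gap to compound 2 lies beyond the usual scatter of repeated measurements, so compound 1 is the stronger inhibitor of this pair. Compound 2 differs from compound 1 in more than one place, so its value says nothing about any single change.

Compound 3, `Cc1ccc2[nH]c(=O)c(/C=N/Nc3ccc([N+](=O)[O-])cc3[N+](=O)[O-])cc2c1`, has not yet been measured in this assay. It differs from compound 1 in one spot: nitro in place of hydrogen on an aromatic carbon. Among the compounds with values here, no measured pair in this set shows what a change of this kind does, so the expected step can only be a guess. Adding a second nitro group to a ring that already carries one is a small change to a compound whose value is already high, and the expectation is a step of modest size, a 1.4-fold lower number from compound 1 to compound 3 (0.13 log units; within the scatter), most likely within the scatter or a little below the value of compound 1. Compound 3 is therefore estimated at 80000 nM in this assay, with a plausible range from 25000 nM to 300000 nM.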

Compound 3, half-maximal inhibitory concentration: "not active" (no number reported)
The entry for compound 3 holds no number, and the estimate cannot be compared.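

In this assay, within the data shown here, compound 3 is recorded only as "not active", without a number, so no step from compound 1 to compound 3 can be read. Nothing shown here offers an explanation for this result.

As far as these compounds go, whether nitro in place of hydrogen on the aromatic ring weakens inhibition, and by how much, remains open.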